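Sulfonamide series: benzylamino in place of fluoro

The source may hold more compounds than are shown below. What is called first, only, known or untested is meant among the compounds shown, and "the series" means these compounds.

For the measured compounds named here, in an assay on VSM-A10 cells for antagonist activity at Endothelin-1 receptor (Rattus norvegicus) (on this read-out lower numbers stand for stronger inhibition and higher numbers for weaker inhibition), compound 2 `Cc1noc(NS(=O)(=O)c2ccc(F)cc2)c1C` gives 1000 nM, the lower of the two numbers so far; compound 1 `Cc1noc(NS(=O)(=O)c2ccc(NCC(=O)O)cc2)c1C` gives 12000 nM. Going by the values given here, the single step known is a 12-fold lower number from compound 1 to compound 2 (1.08 log units; beyond the scatter), a large one. Compound 3 `Cc1noc(NS(=O)(=O)c2ccc(NCc3ccccc3)cc2)c1C` carries the change (benzylamino in place of fluoro on an aromatic carbon), para to a large group. The change returns an amino-bearing group to that aromatic carbon, yet benzylamino differs from (carboxymethyl)amino, so the measured step serves only as a partial guide. For compound 3 a higher number is expected, the step estimated as a 3.0-fold higher number from compound 2 to compound 3 (0.48 log units; beyond the scatter). The estimate for compound 3 is 3000 nM, with a range of 800 nM to 12000 nM.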

Compound 3, half-maximal inhibitory concentration: 9800 nM
The estimate for compound 3 lay 3.3-fold (0.51 log units) below the measured number, within the range that was stated.
By their numbers in this assay, from the lowest: compound 2; then compounds 3 and 1 (each within the scatter of the next).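

Benzylamino brings no gain over fluoro on this aromatic carbon in this assay: there is a 9.8-fold higher number from compound 2 to compound 3 (0.99 log units; beyond the scatter). With a 1.2-fold lower number from compound 1 to compound 3 (0.09 log units; within the scatter), phenyl and carboxy on the saturated chain carbon cannot be told apart, so two quite different amino-bearing groups both leave the number well short of fluoro. No measurement on hand accounts for this.

Still open, from the compounds shown here alone, is whether the shared nitrogen or what it carries sets the number. A plain amine on this aromatic carbon would test that, and a chloro group would show whether fluoro can be bettered.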